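The source may hold more compounds than are shown below. What is called first, only, known or untested is meant among the compounds shown, and "the series" means these compounds.

Measured in an ADME assay on liver for metabolic stability, with Liver microsome (Rattus norvegicus) as the target, read by LC-MS, using microsomes, with a stated time of 5 h; a lower number here means slower removal, a higher number faster removal of the compound:
- compound 1 `O[C@H](c1ccccn1)[C@]1(c2cccc(OC(F)(F)F)c2)C[C@@H](O)C1`: 217 mL/min/kg
- compound 2 `C[C@]1(O)C[C@](c2ccc(OC(F)(F)F)cc2)([C@H](O)c2ccccn2)C1`: 100 mL/min/kg
- compound 3 `C[C@]1(O)C[C@](c2ccc(C(F)(F)F)cc2)([C@H](O)c2ccccn2)C1`: 100 mL/min/kg

Compound 2, at 100 mL/min/kg, stands level with compound 3, at 100 mL/min/kg, and together they hold the lowest number of the three. Compound 1 reads higher, at 217 mL/min/kg.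

Compound 4 `C[C@]1(O)C[C@@](c2ccc(OC(F)(F)F)cc2)([C@@H](O)c2ccccn2)C1` differs from compound 2 only in configuration as drawn: the two compounds have the same atoms and bonds and differ only in configuration as drawn: 2 of 3 stereo elements differ; a stereocentre at a saturated ring carbon is drawn r in compound 2 and s in compound 4; a stereocentre at a saturated chain carbon is drawn S in compound 2 and R in compound 4. Among the compounds with values here, the one measured step between compounds that differ in a single place is no change at the digits printed from compound 2 to compound 3 (within the scatter). That step puts trifluoromethyl in place of trifluoromethoxy on an aromatic carbon and leaves the configuration alone, so it offers only weak guidance here. Within the data shown here, no measured pair shows what a change in configuration does in this assay, and no direction can be argued from these data. The expected result is therefore no change at the digits printed from compound 2 to compound 4 (within the scatter), with no shift beyond the scatter anticipated, though this is a default and not a trend. For compound 4 the estimate is 100 mL/min/kg, with an expected range from 45 mL/min/kg to 220 mL/min/kg.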

Compound 4, clearance: 100 mL/min/kg
Beside the measured number, compound 4's estimate shows no gap at the digits printed; the measured number falls inside the stated range.
By their numbers in this assay, from the lowest: compounds 2, 3 and 4 (each within the scatter of the next); then compound 1.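

Within the data shown here, until now, the only step between closely matched compounds swapped one group on an aromatic carbon, which said nothing about configuration. Here, in this assay, drawing the saturated ring carbon and the saturated chain carbon the other way gives no change at the digits printed from compound 2 to compound 4 (within the scatter), so the clearance reading does not separate these two configurations. This pair can be read as a test of configuration alone because of one structural point: the fact that compounds 2 and 4 differ only in the configuration as drawn.

Both stereocentres change together in this pair, so the compounds shown leave open what either change does on its own. Also open, going by these compounds, is whether configuration would matter just as little with another group on the aromatic carbon, such as an amine or a carboxylic acid in place of trifluoromethoxy.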